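The source may report more compounds than this note shows. Statements on the series, on what has been measured and on what is new or still open speak of the compounds shown alone.

Measured so far:
- compound 1 `CCOc1ccc([C@@H]2CC(=O)c3cc(CC=C(C)C)c(OC)cc3O2)cc1`: 57%
- compound 2 `COc1cc2c(cc1CC=C(C)C)/C(=N/O)C[C@@H](c1ccc(O)cc1)O2`: 93%

In a functional assay on MCF7 cells (Homo sapiens) for inhibition, read by sulforhodamine B assay, with a stated time of 48 h, tested at 50 uM (on this read-out higher numbers stand for more inhibition of growth at the one concentration tested and lower numbers for less inhibition of growth), compound 1 gives 57%, the lower of the two numbers shown; compound 2 stands higher, by a gap beyond the usual scatter. Compound 3 `C#CCOc1ccc([C@@H]2CC(=O)c3cc(CC=C(C)C)c(OC)cc3O2)cc1` is not yet measured. It differs from compound 1 in one place: ethynyl in place of methyl on a saturated chain carbon bound to an oxygen on an aromatic ring. For the measured compounds named here, no pair of measured compounds shows a step of this kind, so the size of the effect is open. The step from compound 1 to compound 3 is expected to be small, a number 3 percentage points higher from compound 1 to compound 3 (within the scatter), and not beyond the scatter. For compound 3 the estimate in this assay is 60%, with a range from 40% to 80%.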

Compound 3, percent growth inhibition at one concentration: 68%
Beside the measured number, compound 3's estimate is 8 percentage points below it; the range from low to high includes it.
By their numbers in this assay, from the lowest: compound 1; then compound 3; then compound 2.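

In this assay, for the compounds shown here, the change from ethoxy to propargyloxy gives the first readable step at this position: a number 11 percentage points higher from compound 1 to compound 3 (beyond the scatter). The position on the saturated chain carbon bound to the aromatic oxygen therefore responds to this change, modestly, and the larger group keeps growth inhibition rather than losing it. Nothing at hand accounts for the gain. Going by these compounds, whether it follows from the triple bond or from chain length alone stays open; a propyl ether would separate the two. An amine at the chain end remains an untested direction in the compounds shown.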